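The source may hold more compounds than are shown below. What is called first, only, known or untested is meant among the compounds shown, and "the series" means these compounds.

Measured compounds:
compound 1 `Cc1cc(C(N)=O)nn1Cc1cc(Cl)ccc1OCc1ccccc1`: in an assay on CHO-K1 cells for displacement of a labelled ligand from prostaglandin E2 receptor EP1 subtype (Homo sapiens) (on this read-out lower numbers stand for stronger inhibition and higher numbers for weaker inhibition), compound 1 gives 126 nM
compound 2 `Cc1cc(NC(=O)c2ccccc2)nn1Cc1cc(Cl)ccc1OCc1ccccc1`: in this assay compound 2 gives 15.9 nM

Among the measured compounds shown here, compound 2 stands lowest of the two numbers, the only other being compound 1, reached through a 7.9-fold lower number from compound 1 to compound 2 (0.90 log units; beyond the scatter). Compound 3 `O=C(Nc1ccn(Cc2cc(Cl)ccc2OCc2ccccc2)n1)c1ccccc1` differs from compound 2 in one place: hydrogen in place of methyl on an aromatic carbon. For the measured compounds named here, no measured step bears on this change. Going by the values given here, the single step recorded so far alters the group on the other carbon of the shared core, benzamido in place of carbamoyl, and leaves the methyl untouched, so there is no direct precedent for removing it. The step is therefore expected to be no larger than the scatter, with a slight lean toward a higher number, that is a 1.6-fold higher number from compound 2 to compound 3 (0.20 log units; within the scatter). Compound 3 is accordingly estimated at 25 nM, within a range from 8 nM to 80 nM.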

Compound 3, half-maximal inhibitory concentration: 251 nM
Estimate against measurement, compound 3: 10-fold (1.00 log units) below, and the stated range ends below it.
By their numbers in this assay, from the lowest: compound 2; then compounds 1 and 3 (each within the scatter of the next).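

In this assay, the methyl on this aromatic carbon of the five-membered ring proves to count for a great deal: putting hydrogen in its place gives a 16-fold higher number from compound 2 to compound 3 (1.20 log units; beyond the scatter), a large step for a change of one heavy atom. The earlier step left the methyl untouched, so only now is it clear that this position, next to the ring atom that bears a large group, responds strongly while the benzamido group stays in place. No measurement at hand accounts for the size of this step.

The compounds shown carry only methyl or hydrogen here, so it remains open how an ethyl group, a chlorine atom or a methoxy group would fare at this carbon. On these data alone, it also remains open whether removing the methyl costs as much with carbamoyl in place of benzamido.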